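The compounds below may be only part of what the source reports. "The series", "measured", "known", "first", "only" and "open" are said of these compounds alone.

Compound 1, `O=C(Nc1cc(Cl)cc(Cl)c1)c1cncnc1C(F)(F)F`, is one of two compounds whose potency has been recorded. In an assay on Jurkat cells for inhibition of nuclear factor NF-kappa-B p105 subunit (Homo sapiens) (on this read-out higher numbers stand for weaker inhibition and lower numbers for stronger inhibition), compound 1 reaches only a limit of the assay, > 10000 nM. Compound 2, `CCCCNC(=O)c1cc(NC(=O)c2cnc(Cl)nc2C(F)(F)F)cc(C(F)(F)F)c1`, is the other recorded compound, and in this assay compound 2 likewise stops at a limit, > 10000 nM. Going by the values given here, both recorded values therefore sit at the same place, (the limit of > 10000 nM in this assay, at which 2 of the 2 values shown sit), so no numerical difference between compound 1 and compound 2 can be stated, and no step between measured compounds exists from which to judge the size of a structural change.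

Compound 3, `CCCCCCOC(=O)c1cc(NC(=O)c2cnc(Cl)nc2C(F)(F)F)cc(C(F)(F)F)c1`, has not yet been measured. It differs from compound 2 in one place: hexyloxy in place of butylamino on a carbonyl carbon. With both recorded compounds at the limit, the available numbers give no indication that a change of this kind moves potency below the limit, and compound 3 is expected to remain weak. The step from compound 2 to compound 3 in this assay is therefore expected to be a step that the limit leaves unreadable from compound 2 to compound 3, none beyond the scatter. The value estimated for compound 3 in this assay is 12000 nM, within a range from 3000 nM to 50000 nM, most probably reported only as a limit.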

Compound 3, half-maximal inhibitory concentration: 620 nM
Compound 3: middle estimate off by 19-fold (1.29 log units), on the high side; measured number outside the range, below it.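

Compound 3 is the first compound shown to leave the assay limit, so the group on this carbonyl carbon can decide whether the series reads at all in this assay: hexyloxy in place of butylamino gives an at least 16-fold lower number from compound 2 to compound 3 (1.20 log units; beyond the scatter). Going by these compounds, the true size of this step stays unknown, and it can be stated only as a minimum because compound 2 stands at a limit of the assay: the limit of > 10000 nM in this assay, at which 2 of the 3 values shown sit. The change also alters two things at once, since nitrogen gives way to oxygen at the carbonyl carbon, with the loss of the amide hydrogen, while the butyl chain gives way to a hexyl chain, so the step cannot be assigned to either alone.

The compounds shown leave open which of these two parts matters, and a hexylamino group or a butoxy group on the same carbonyl carbon would pull them apart. They also leave open how far the trend runs along the chain, for instance with an octyloxy group, and whether a carboxylic acid in this place would keep any of the potency of compound 3.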